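The compounds below may be only part of what the source reports. "The series", "measured", "known", "first", "only" and "open" are said of these compounds alone.

For the measured compounds named here, in an assay on MDA-MB-231 cells for binding affinity to C-X-C chemokine receptor type 4 (Homo sapiens), read by fluorescence and microscopy, with stated times of 10 min and 30 min (on this read-out higher numbers stand for an effect only at larger amounts of compound and lower numbers for an effect already at smaller amounts), three compounds carry a value so far. Compound 1 `O=C(NCc1ccc(CNS(=O)(=O)c2ccc3c(c2)CCO3)cc1)c1ccc(F)cc1` gives 10 nM. Compound 2 `Cc1ccccc1S(=O)(=O)NCc1ccc(CNC(=O)c2ccc(F)cc2)cc1` gives 100 nM, the higher of the two numbers, and its nearest neighbour is compound 1, the step being a 10-fold higher number from compound 1 to compound 2 (1.00 log units; beyond the scatter). Compound 3 `Cc1ccc(S(=O)(=O)NCc2ccc(CNC(=O)c3ccc(F)nc3)cc2)cc1` gives only a limit of the assay, > 1000 nM, which is the case described by the limit of > 1000 nM in this assay, at which 1 of the 3 values shown sits.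

Compound 4 `O=C(NCc1ccc(CNS(=O)(=O)c2ccc([N+](=O)[O-])cc2)cc1)c1ccc(F)cc1` has not yet been measured. It differs from compound 2 in one place: 4-nitrophenyl in place of 2-methylphenyl on a sulfonyl sulfur. Going by the values given here, of the measured steps, only the one from compound 1 to compound 2 touches the same place, the group on the sulfonyl sulfur, and there a change of ring at that position moved the number by a modest but real amount, beyond the scatter. Among the compounds with values here, compound 3 also carries a different ring at that position but differs elsewhere too, and its value is a limit, so it gives no step. For compound 4 a step of no change at the digits printed from compound 2 to compound 4 (within the scatter) is expected, and the estimated value is 100 nM, within a range of 30 nM to 400 nM.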

Compound 4, effective concentration (reported as EC, without a stated level of effect): 1000 nM
For compound 4 the middle estimate is 10-fold (1.00 log units) below the measured one; measured number outside the range, above it.
By their numbers in this assay, from the lowest: compound 1; then compound 2; then compound 4.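

Replacing 2-methylphenyl with 4-nitrophenyl on the sulfonyl sulfur gives a 10-fold higher number from compound 2 to compound 4 (1.00 log units; beyond the scatter) in this assay, so a change at this position moves the number beyond the scatter even when the group entering and the group leaving each hold one six-membered aromatic ring of carbon only. Across the compounds that differ only in this group, the span widens to a 100-fold higher number from compound 1 to compound 4 (2.00 log units; beyond the scatter), which shows a far larger range at this position than the earlier step alone revealed. Compound 4 now stands at the same figure as the only limit in this assay: the limit of > 1000 nM in this assay, at which 1 of the 4 values shown sits.

The compounds shown do not separate the change of group from the change of its ring position, as the methyl and nitro groups are named at different positions on the phenyl ring. On these data alone, how 4-aminophenyl or 4-carboxyphenyl on the sulfonyl sulfur of the same core would read remains open.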